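Alkynyl nucleoside series: propyl to phenyl on the alkyne

The compounds below may be only part of what the source reports. "The series", "measured", "known", "first", "only" and "open" are said of these compounds alone.

Compound 3 `CCCC#Cc1cn([C@H]2C[C@H](O)[C@@H](CO)O2)c(=O)[nH]c1=O` is recorded in a functional assay on L1210 cells (Mus musculus) (a lower number here means a stronger inhibitor, a higher number a weaker inhibitor), only as a limit, at > 1000 ug/mL. That places compound 3 at the limit of > 1000 ug/mL in this assay, at which 1 of the 3 values shown sits. Its neighbours in the series give numbers: compound 1 `COCC#Cc1cn([C@H]2C[C@H](O)[C@@H](CO)O2)c(=O)[nH]c1=O` gives 254 ug/mL, and compound 2 `CCCCCC#Cc1cn([C@H]2C[C@H](O)[C@@H](CO)O2)c(=O)[nH]c1=O` gives 219 ug/mL, so that the step of a 1.2-fold lower number from compound 1 to compound 2 (0.06 log units; within the scatter) lies within the scatter. Both steps that end at compound 3 run toward weaker inhibition: an at least 3.9-fold higher number from compound 1 to compound 3 (0.59 log units; beyond the scatter) and an at least 4.5-fold higher number from compound 2 to compound 3 (0.65 log units; beyond the scatter).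

Compound 4 `O=c1[nH]c(=O)n([C@H]2C[C@H](O)[C@@H](CO)O2)cc1C#Cc1ccccc1` differs from compound 3 by phenyl in place of propyl on a triple-bonded carbon. Going by the values given here, the two measured steps that end at compound 3 both change what the alkyne carries and both are at least modest, but neither involves phenyl, so the new group has no measured counterpart. The data only show that the two substituents other than propyl gave numbers while propyl gave a limit. For compound 4 a number rather than a further limit is expected, with low confidence. For compound 4 the expected step is an at least 2.0-fold lower number from compound 3 to compound 4 (0.30 log units; that floor lies within the scatter). The estimate for compound 4 is 500 ug/mL, ranging from 150 ug/mL to 1500 ug/mL.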

Compound 4, concentration for 50% inhibition: 494 ug/mL
Beside the measured number, compound 4's estimate is 1.0-fold (0.01 log units) above it; low and high end bracket the measured number.
By their numbers in this assay, from the lowest: compounds 2, 1 and 4 (each within the scatter of the next, the first and the last beyond it). At a limit, above all of these: compound 3.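

Phenyl in place of propyl on the triple-bonded carbon gives, in this assay, an at least 2.0-fold lower number from compound 3 to compound 4 (0.30 log units; that floor lies within the scatter), so a ring at this position yields a number, though the size of this change remains unfixed. Set against the other substituents, the ring gives a 1.9-fold higher number from compound 1 to compound 4 (0.29 log units; within the scatter), and a 2.3-fold higher number from compound 2 to compound 4 (0.35 log units; beyond the scatter), so phenyl separates from pentyl but not from methoxymethyl. Compound 3 remains a limit, not a number: the limit of > 1000 ug/mL in this assay, at which 1 of the 4 values shown sits.

Propyl still stands alone among the four substituents in giving only a limit, and the shown compounds do not tie that to any single feature of the group. From the compounds shown here alone, whether a substituted phenyl, such as a methoxyphenyl, or a chain ending in an amine or a carboxylic acid would change the reading at this position stays open.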